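The source may hold more compounds than are shown below. What is called first, only, known or untested is meant among the compounds shown, and "the series" means these compounds.

The series shares one core, seen in compound 1 `Cc1cc(NC(=O)Cn2nnc(-c3ccccc3)n2)n(C2CCS(=O)(=O)CC2)n1` and compound 2 `Cc1cc(NC(=O)Cn2nnc(-c3ccccn3)n2)n(C2CCCCC2)n1`. In an assay on HEK293 cells for activation of Kir3.1/Kir3.2 (Homo sapiens), read by thallium flux (a lower number here means a smaller maximal response, a higher number a larger maximal response), compound 1 gives > 25%, which is a limit of the assay and not a number (the limit of > 25% in this assay, at which 1 of the 2 values shown sits). In this assay, within the data shown here, compound 2 gives 81%, the only number so far. Compound 3 `Cc1cc(NC(=O)Cn2nnc(-c3cccc(F)c3)n2)n(C2CCCCC2)n1` is not yet measured. It differs from compound 2 in one place: 3-fluorophenyl in place of pyridin-2-yl on an aromatic carbon. Among the measured compounds shown here, no step between measured compounds is available, so the size of this change is open; a shift in this assay in either direction beyond the scatter cannot be excluded, and a small downward step is taken as the working expectation. Compound 3 is expected to give about 65% in this assay, within 30% to 95%. The expected step of a number 16 percentage points lower from compound 2 to compound 3 (beyond the scatter) is thus modest.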

Compound 3, largest response reached (Emax), in percent of the reference or control that the assay uses: 96%
Estimate against measurement, compound 3: 31 percentage points below; the whole stated range lies below it.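

In this assay, among these compounds, replacing pyridin-2-yl with 3-fluorophenyl on the aromatic carbon of the five-membered aromatic ring with 4 nitrogen gives the first readable step: a number 15 percentage points higher from compound 2 to compound 3 (beyond the scatter). A large maximal response at this position therefore does not depend on the ring nitrogen or the hydrogen-bond acceptor of pyridin-2-yl: compound 3, which has neither, gives 96%. No measurement shown gives a reason for this step.

Among the compounds shown here, the step combines loss of the ring nitrogen with entry of fluorine, so the share of each cannot be read, and no step involving compound 1 can be read. As far as these compounds go, how this assay responds to an amine or a carboxylic acid in place of the fluorine remains open.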